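The source may report more compounds than this note shows. Statements on the series, on what has been measured and on what is new or still open speak of the compounds shown alone.

Compound 3 `COc1cc(Cl)cc(-c2nn(-c3cccc(NC(=O)Nc4ccc(Cl)c(C(F)(F)F)c4)c3)cc2-c2ccncc2)c1` was tested in a functional assay on SNB-19 cells (Homo sapiens) for inhibition, read by sulforhodamine B assay, with a stated time of 48 h, tested at 0.1 uM (a higher number here means a weaker effect of the compound at the concentration tested, a lower number a stronger effect), and gives 95%. Compound 1 `O=C(Nc1cccc(-n2cc(-c3ccncc3)c(-c3cc(O)cc(Cl)c3)n2)c1)Nc1ccc(Cl)c(C(F)(F)F)c1` gives 95% in this assay, and compound 2 `O=C(Nc1cccc(-n2cc(-c3ccncc3)c(-c3cc(O)cc(Cl)c3)n2)c1)Nc1ccc(Cl)c(Cl)c1` gives 95% in this assay. Compound 3 therefore stands level with compounds 1 and 2 at the digits shown: the step of no change at the digits printed from compound 1 to compound 3 (within the scatter) puts it nearest compound 1, and its value and that of compound 2 lie within the scatter of each other. Compound 4 `COc1cc(Cl)cc(-c2nn(-c3cccc(NC(=O)Nc4ccc(Cl)c(Cl)c4)c3)cc2-c2ccncc2)c1` has not yet been measured. It differs from compound 3 in one place: chloro in place of trifluoromethyl on an aromatic carbon. The same change has been measured once within this small set, from compound 1 to compound 2, where no change at the digits printed from compound 1 to compound 2 (within the scatter). The other measured step, no change at the digits printed from compound 1 to compound 3 (within the scatter), concerns a different place on the shared core and likewise stayed within the scatter. Because compound 2 gives 95% after the same change, no step beyond the scatter is expected for compound 4 in this assay. The expected step of no change at the digits printed from compound 3 to compound 4 (within the scatter) is accordingly within the scatter. Compound 4 is estimated at 95% in this assay, with a range from 85% to 103%.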

Compound 4, a percentage reported as activity, at one concentration (the size of the read-out at that concentration, not a potency): 90%
The estimate for compound 4 lay 5 percentage points above the measured number; the range from low to high includes it.
By their numbers in this assay, from the lowest: compounds 4, 1, 2 and 3 (each within the scatter of the next).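

In this assay the change from 4-chloro-3-(trifluoromethyl)phenyl to 3,4-dichlorophenyl now has a second reading, on the core that carries a methyl on the oxygen, where it gives a number 5 percentage points lower from compound 3 to compound 4 (within the scatter), and this agrees with its first reading: the same change on two cores in this assay, no change at the digits printed (within the scatter) from compound 1 to compound 2 and a number 5 percentage points lower (within the scatter) from compound 3 to compound 4, 5 percentage points apart, within the scatter of two such steps. The methyl on the oxygen also gains a second reading, this time on the compounds with the 3,4-dichlorophenyl group, where it gives a number 5 percentage points lower from compound 2 to compound 4 (within the scatter), and this again agrees with the earlier step: the same change on two cores in this assay, no change at the digits printed (within the scatter) from compound 1 to compound 3 and a number 5 percentage points lower (within the scatter) from compound 2 to compound 4, 5 percentage points apart, within the scatter of two such steps. Across these four compounds, neither change has therefore moved the read-out beyond the scatter on either core, whichever of the two groups is present at the other site.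

As far as these compounds go, it remains open whether a group of another kind at the position of the trifluoromethyl, such as an amine, a nitrile or a carboxylic acid, would give a number beyond the scatter of these four. From the compounds shown here alone, these are readings at a single concentration and not potencies, so any differences among the compounds that would appear only at other concentrations remain unknown.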